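Working notes: from compound 2 to compound 3

A few compounds are considered here, and "the series" means these few. Any claim that something is new, unique, unknown or untested is made for them only; others in the source may bear on it.

Values in a functional assay on HepG2 cells (Homo sapiens) for cytotoxicity, read by MTT assay; on this read-out higher numbers stand for weaker inhibition and lower numbers for stronger inhibition:
- compound 1 `C=CCOc1cc(/C=C/C(=O)c2ccc(OC)c3c2OC(C)(C)C=C3)ccc1OC`: > 10000 nM, a limit and not a number
- compound 2 `COc1cccc(C(=O)Oc2cc(/C=C/C(=O)c3ccc(OC)c4c3OC(C)(C)C=C4)ccc2OC)c1`: 870 nM

For the measured compounds named here, compound 2 carries the only actual number so far, as the other entry is a limit. Compound 3 `COc1ccc(/C=C/C(=O)c2ccc(OC)c3c2OC(C)(C)C=C3)cc1OS(=O)(=O)c1ccc(C)cc1` has not yet been measured. The change is (4-methylphenyl)sulfonyl in place of (3-methoxyphenyl)carbonyl on an oxygen on an aromatic ring.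

Going by the values given here, one measured step bears on this: an at least 11-fold lower number from compound 1 to compound 2 (1.06 log units; beyond the scatter), made at the same oxygen, with (3-methoxyphenyl)carbonyl in place of allyl. That step was large, so the group on this oxygen can shift the number strongly. Unlike allyl, the entering group shares a six-membered aromatic ring of carbon only with the leaving group. Among the compounds with values here, no measured step covers a sulfonyl group, however. Compound 2 at 870 nM therefore serves as the anchor, and no step beyond the scatter is expected in this assay, with the greater risk towards higher numbers. The expected result is a 1.7-fold higher number from compound 2 to compound 3 (0.24 log units; within the scatter). For compound 3 the estimated value is 1500 nM, with an expected range of 300 nM to 7000 nM.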

Compound 3, half-maximal inhibitory concentration: 3600 nM
Estimate against measurement, compound 3: 2.4-fold (0.38 log units) below, and the stated range covers the measured number.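

In this assay, (4-methylphenyl)sulfonyl in place of allyl gives an at least 2.7-fold lower number from compound 1 to compound 3 (0.44 log units; beyond the scatter), so (3-methoxyphenyl)carbonyl is no longer the only group shown to lower the number from that of the allyl compound at this oxygen on an aromatic ring. The two entering groups are still not interchangeable: each carries one six-membered aromatic ring of carbon only, yet the exchange gives a 4.1-fold higher number from compound 2 to compound 3 (0.62 log units; beyond the scatter), so the presence of that ring does not by itself set the number. Compound 1 stands at a limit and not at a number, which makes both steps from it bounds rather than measured sizes: the limit of > 10000 nM in this assay, at which 1 of the 3 values shown sits.

The compounds shown leave open whether the gap between the two aromatic groups follows the carbonyl or sulfonyl link or the substituent on the ring, since the 3-methoxyphenyl and 4-methylphenyl parts change together with the link. Going by these compounds, how a small acetyl group, a benzyl group, a chain ending in an amine or a free hydroxyl on this oxygen would read in this assay also remains open.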